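This account rests on a few compounds, and the source may have more. Where it says the series, first, only, none or still open, it means among the compounds named here.

Measured so far:
compound 1 `C=CCc1ccc(OCc2cn(-c3cccc([N+](=O)[O-])c3)nn2)c(O)c1`: 15.2%
compound 2 `C=CCc1cc(O)c(O)c(CN2CCC(C)CC2)c1`: 57.6%

In a functional assay on HepG2 cells (Homo sapiens) for inhibition, read by MTT assay, with a stated time of 72 h, tested at 30 uM (a higher number here means more inhibition of growth at the concentration tested, a lower number less inhibition of growth), compound 2 stands highest of the two numbers at 57.6% and compound 1 lies lower at 15.2% by a gap beyond the scatter. These two compounds differ in more than one place, so their gap says nothing about any single change.

Within the data shown here, compound 3 `C=CCc1cc(O)c(O)c(CN2CCC(CCO)CC2)c1` has no measurement yet. It differs from compound 2 by hydroxymethyl in place of hydrogen on a saturated chain carbon bound to a saturated ring carbon with hydroxymethyl in place of hydrogen on a saturated chain carbon bound to a saturated ring carbon, which also reads as methyl to 2-hydroxyethyl. Among the measured compounds shown here, no measured pair shows this change, so the expectation rests on compound 2 at 57.6% alone and stays loose. A modest fall in this assay is expected, possibly none beyond the scatter. The expected step of a number 8.6 percentage points lower from compound 2 to compound 3 (within the scatter) is a small one. For compound 3 the estimated value is 49% with an expected range from 30% to 66% for now.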

Compound 3, percent growth inhibition at one concentration: 2.5%
Compound 3: the middle estimate sits 46.5 percentage points above what was measured, and the stated range ends above it.
By their numbers in this assay, from the lowest: compound 3; then compound 1; then compound 2.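

In this assay, the series now holds its first pair differing in one place, and the change is far from silent: hydroxymethyl in place of hydrogen on a saturated chain carbon bound to a saturated ring carbon, which also reads as methyl to 2-hydroxyethyl, gives a number 55.1 percentage points lower from compound 2 to compound 3 (beyond the scatter). This position therefore does not accept every extension: the methyl of compound 2 goes with clear growth inhibition, whereas the 2-hydroxyethyl of compound 3 goes with little, although this rests on a single pair. No measurement at hand accounts for the loss.

Open, from the compounds shown here alone, is whether the loss follows the added chain length or the oxygen at its end: an ethyl or propyl group at this place would separate the two, and a methoxyethyl group or a carboxylic acid would probe the end of the chain further. Also open, going by these compounds, is whether the step holds on another core, since compound 1 differs from compound 2 in more than one place and gives no reading on this change.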